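Swapping fluoro for chloro on the pendant phenyl ring

The source may hold more compounds than are shown below. What is called first, only, known or untested is meant among the compounds shown, and "the series" means these compounds.

Measured so far:
Compound 1 `CC(C)=CCOc1ccc2c(c1)OC(c1ccccc1)CC2=O` — 6070 nM
Compound 2 `CC(C)=CCOc1ccc2c(c1)OC(c1ccccc1F)CC2=O` — 6360 nM

In a functional assay (on this read-out lower numbers stand for stronger inhibition and higher numbers for weaker inhibition), compound 2 gives 6360 nM, the higher of the two numbers, though the step of a 1.0-fold higher number from compound 1 to compound 2 (0.02 log units; within the scatter) lies within the scatter. Compound 3 `CC(C)=CCOc1ccc2c(c1)OC(c1ccccc1Cl)CC2=O` differs from compound 2 by one change, (chloro in place of fluoro on an aromatic carbon). Among the compounds with values here, only one measured step bears on this position, and it was a 1.0-fold higher number from compound 1 to compound 2 (0.02 log units; within the scatter), so adding fluoro there changed nothing beyond the scatter. Compound 3 is therefore expected to sit close to compound 2, with a step of a 1.2-fold lower number from compound 2 to compound 3 (0.06 log units; within the scatter). The estimate for compound 3 is 5500 nM, within 2500 nM to 12000 nM.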

Compound 3, half-maximal inhibitory concentration: 8020 nM
Compound 3: middle estimate off by 1.5-fold (0.16 log units), on the low side; measured number inside the range.
By their numbers in this assay, from the lowest: compounds 1, 2 and 3 (each within the scatter of the next).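

In this assay chloro in place of fluoro on this aromatic carbon gives a 1.3-fold higher number from compound 2 to compound 3 (0.10 log units; within the scatter) and chloro in place of hydrogen gives a 1.3-fold higher number from compound 1 to compound 3 (0.12 log units; within the scatter) so neither step on this ring separates the compounds. Hydrogen, fluoro and chloro at this place therefore cannot be told apart on this read-out, which the fluoro step alone could not show. Nothing available explains this result. The compounds shown leave open whether a different kind of group at this place, such as an amine or a carboxylic acid, would give a step beyond the scatter.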